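This account rests on a few compounds, and the source may have more. Where it says the series, first, only, none or still open, it means among the compounds named here.

Measured compounds:

Compound 1, `CC1CCN(c2c(S(=O)(=O)c3ccc(Cl)c(Cl)c3)cnc3ccc(Cl)cc23)CC1`, gives 86% in an assay on isolated protein for displacement of a labelled ligand from metabotropic glutamate receptor 5 (Homo sapiens), with a stated time of 60 min, tested at 1 uM; a higher number here means more inhibition at the concentration tested (going by the name of the read-out), a lower number less inhibition.
Compound 2, `CC1CCN(c2c(S(=O)(=O)c3ccc(C#N)cc3)cnc3cc(Cl)ccc23)CC1`, gives 70% in this assay.
Compound 3, `CC1CCN(c2c(S(=O)(=O)c3ccc(C#N)cc3)cnc3cc(F)ccc23)CC1`, gives 83% in this assay.

Of the three numbers, compound 2 stands lowest; compound 3 is nearest to it, with the step of a number 13 percentage points higher from compound 2 to compound 3 (beyond the scatter), and compound 1 is furthest from it, the two values lying beyond the scatter of each other.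

Compound 4, `COc1cccc(S(=O)(=O)c2cnc3cc(Cl)ccc3c2N2CCC(C)CC2)c1`, is not yet measured. It differs from compound 2 in one place: 3-methoxyphenyl in place of 4-cyanophenyl on a sulfonyl sulfur. Among the measured compounds shown here, the only step measured within this set, a number 13 percentage points higher from compound 2 to compound 3 (beyond the scatter), concerns a change on the shared core, not on the group attached to the sulfonyl sulfur, so no measured step speaks directly to the change from compound 2 to compound 4. Compound 1 also carries a different group on the sulfonyl sulfur, but it differs from compound 2 in more than one place and gives no isolated comparison. All three measured compounds lie in a fairly narrow band of numbers, but the direction of the change to a 3-methoxyphenyl cannot be read from these data. The expected step is therefore small and uncertain, estimated as a number 5 percentage points lower from compound 2 to compound 4 (within the scatter). Compound 4 is expected to give about 65%, with a range from 35% to 88%.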

Compound 4, a percentage reported as inhibition, at one concentration (the size of the read-out at that concentration, not a potency): 93%
Compound 4: middle estimate off by 28 percentage points, on the low side; measured number above the stated range.
By their numbers in this assay, from the lowest: compound 2; then compounds 3, 1 and 4 (each within the scatter of the next).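

In this assay the group on the sulfonyl sulfur can move the reading on its own with the shared core held fixed, as 3-methoxyphenyl in place of 4-cyanophenyl gives a number 23 percentage points higher from compound 2 to compound 4 (beyond the scatter) here. Among the compounds shown here, the earlier single-place step concerned only the core, and compound 1 differs from compound 2 in more than one place, so this is the first clean comparison at this position. The data offer no measured explanation for why this change raises the number.

A plain phenyl, a 4-methoxyphenyl or a 3-cyanophenyl on the sulfonyl sulfur would be needed to separate the loss of the nitrile from the arrival of the methoxy group and to show whether the place of each group on the ring matters. From the compounds shown here alone, it also remains open whether 3-methoxyphenyl would give a similar step on the fluoro core of compound 3.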